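Three Carbamates Measured, a Fourth Still to Be Read

A few compounds are considered here, and "the series" means these few. Any claim that something is new, unique, unknown or untested is made for them only; others in the source may bear on it.

Compound 1, `CC(C)=CCC1Cc2c(OC(=O)Nc3cccc(C(F)(F)F)c3)cc(=O)n(CCCO)c2CC1(C)C`, gives 0% in a functional assay on PANC-1 cells (Homo sapiens) for inhibition, read by MTT assay, with a stated time of 24 h, tested at 10 uM; a lower number here means less inhibition, a higher number more inhibition at the concentration tested (going by the name of the read-out).
Compound 2, `CC(C)=CCC1Cc2c(OC(=O)Nc3ccc(Cl)c(Cl)c3)cc(=O)n(CCCO)c2CC1(C)C`, gives 1.8% in this assay.
Compound 3, `CC(C)=CCC/C(C)=C/CC1Cc2c(OC(=O)Nc3cccc(C(F)(F)F)c3)cc(=O)n(CCCO)c2CC1(C)C`, gives 6.7% in this assay.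

All three share a carbamate carrying a substituted phenyl on its nitrogen, and all three sit low in this assay, with every gap between them inside the usual scatter. Compound 4, `CC(C)=CCC/C(C)=C/CC1Cc2c(OC(=O)Nc3ccc(Cl)c(Cl)c3)cc(=O)n(CCCO)c2CC1(C)C`, has not yet been measured. It differs from compound 3 by 3,4-dichlorophenyl in place of 3-(trifluoromethyl)phenyl on an amide-type nitrogen. The same change has already been made once, between compound 1 and compound 2, as 3,4-dichlorophenyl in place of 3-(trifluoromethyl)phenyl on an amide-type nitrogen, and there it gave a number 1.8 percentage points higher from compound 1 to compound 2 (within the scatter). The place of the change is described in the same words in both pairs, so this counts as the same change. The two cores differ by 3-methylbut-2-en-1-yl in place of hydrogen on a saturated chain carbon bound to a double-bonded chain carbon, a change that by itself gave a number 6.7 percentage points higher from compound 1 to compound 3 (within the scatter).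

Because the earlier instance of this change gave a number 1.8 percentage points higher from compound 1 to compound 2 (within the scatter), the step expected from compound 3 is a number 2.3 percentage points higher from compound 3 to compound 4 (within the scatter), small and within the scatter, resting on that single precedent. Compound 4 is therefore estimated at 9% in this assay, with a likely range from 0% to 20%.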

Compound 4, a percentage reported as inhibition, at one concentration (the size of the read-out at that concentration, not a potency): 0%
Compound 4: middle estimate off by 9 percentage points, on the high side; low and high end bracket the measured number.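

Replacing 3-(trifluoromethyl)phenyl with 3,4-dichlorophenyl on the amide-type nitrogen gives a number 6.7 percentage points lower from compound 3 to compound 4 (within the scatter), and this step does not differ beyond the scatter from its earlier counterpart: the same change on two cores in this assay, a number 1.8 percentage points higher (within the scatter) from compound 1 to compound 2 and a number 6.7 percentage points lower (within the scatter) from compound 3 to compound 4, 8.5 percentage points apart, within the scatter of two such steps
Adding 3-methylbut-2-en-1-yl to the chain gives a number 1.8 percentage points lower from compound 2 to compound 4 (within the scatter), and the same holds for this second pair of steps: the same change on two cores in this assay, a number 6.7 percentage points higher (within the scatter) from compound 1 to compound 3 and a number 1.8 percentage points lower (within the scatter) from compound 2 to compound 4, 8.5 percentage points apart, within the scatter of two such steps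
So in this assay each change behaves alike on both cores as far as these numbers can tell, but every step is within the scatter, so this shows only that neither change produced a measurable effect here, not that either change would carry over to a compound with a clearly higher reading.

The compounds shown leave open whether a carbamate nitrogen bearing a simple alkyl chain or a benzyl group, rather than a substituted phenyl, would give a different reading. They also leave open what an amine or a carboxylic acid in place of the hydroxyl group on the hydroxypropyl chain would do.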